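A few compounds are considered here, and "the series" means these few. Any claim that something is new, unique, unknown or untested is made for them only; others in the source may bear on it.

Series notes. Compound 1 `N#Cc1ccc(NC(=O)c2cc(F)ccc2O)cc1` and compound 3 `N#Cc1ccc(NC(=O)c2cc(Cl)ccc2O)cc1` share a core; compound 2 `O=C(Nc1ccc(OC(F)(F)F)c(Cl)c1)c1cc(F)ccc1O` carries the same acyl part on a different aniline, and the difference between the two cores is not broken down here. In a functional assay on KG-1 cells (Homo sapiens) for cytotoxicity, read by luminescence and CellTiter-Glo, with a stated time of 3 days (on this read-out higher numbers stand for weaker inhibition and lower numbers for stronger inhibition), compound 1 gives 2670 nM, compound 3 gives 1860 nM, and compound 2 gives 370 nM, the lowest number of the three, with compound 3 and compound 1 both beyond the scatter above it.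

Among the measured compounds shown here, the one single-point change measured so far is chloro in place of fluoro on an aromatic carbon. The step of a 1.4-fold lower number from compound 1 to compound 3 (0.16 log units; within the scatter) is small and sits within the scatter, so on the core of compound 1 the swap is close to neutral.

Compound 4 `O=C(Nc1ccc(OC(F)(F)F)c(Cl)c1)c1cc(Cl)ccc1O` has not yet been measured in this assay. For the measured compounds named here, its difference from compound 2 is chloro in place of fluoro on an aromatic carbon, the same change as the one from compound 1 to compound 3, at a place described in identical words. Expectation for compound 4 rests on the step of a 1.4-fold lower number from compound 1 to compound 3 (0.16 log units; within the scatter): a step of similar size, a 1.3-fold lower number from compound 2 to compound 4 (0.12 log units; within the scatter), is expected, giving an estimated 280 nM for compound 4, with a range from 130 nM to 600 nM.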

Compound 4, half-maximal inhibitory concentration: 460 nM
Compound 4: middle estimate off by 1.6-fold (0.22 log units), on the low side; low and high end bracket the measured number.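

In this assay, chloro in place of fluoro on an aromatic carbon para to a hydroxy group gives a 1.2-fold higher number from compound 2 to compound 4 (0.09 log units; within the scatter), so the swap is close to neutral on the core of compound 2, as it is on the core of compound 1. The two steps agree as far as this read-out can tell: the same change on two cores in this assay, a 1.4-fold lower number (0.16 log units; within the scatter) from compound 1 to compound 3 and a 1.2-fold higher number (0.09 log units; within the scatter) from compound 2 to compound 4, 1.8-fold (0.25 log units) apart, within the scatter of two such steps

This shows that, across these two cores, the swap carries over without a step beyond the scatter; it does not give either step a real direction, and two cores set no rule for the wider series.

The compounds shown hold only fluoro and chloro at this place, so it stays open whether a methoxy group or an amine there would give a step beyond the scatter. Also open, from the compounds shown here alone, is whether a carboxylic acid in place of the hydroxy group would leave the number within the scatter on either core.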